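A few compounds are considered here, and "the series" means these few. Any claim that something is new, unique, unknown or untested is made for them only; others in the source may bear on it.

In an ADME assay on K562 cells (Homo sapiens) for cytotoxicity, read by MTT assay, with a stated time of 24 h (a higher number here means that more compound is tolerated, a lower number that less compound is tolerated), compound 1 `Cc1ccc(OC(CCn2ccnc2)c2ccccc2)cc1` gives 95900 nM and compound 2 `Cc1ccc(OC(CCn2ccnc2)c2ccc(C)cc2)cc1` gives 191000 nM. Among the compounds with values here, compound 2 holds the higher of only two numbers, but a 2.0-fold higher number from compound 1 to compound 2 (0.30 log units; within the scatter) lies within the scatter, so the two compounds cannot really be told apart. Both sit at a similar level on this scale.

Compound 3 `Cc1ccc(C(CCn2ccnc2)Oc2ccc(C)cc2Cl)cc1` differs from compound 2 by a single change: chloro in place of hydrogen on an aromatic carbon. This is chloro in place of hydrogen on an aromatic carbon, turning a 4-methylphenyl into a 2-chloro-4-methylphenyl. Within the data shown here, no measured pair shows what chloro does here. The nearest evidence is a different swap, methyl in place of hydrogen on an aromatic carbon, so it offers only a loose guide. Because a 2.0-fold higher number from compound 1 to compound 2 (0.30 log units; within the scatter) stayed within the scatter, no step beyond the scatter is expected in this assay, and no firm direction can be claimed. The expected change is a 1.3-fold lower number from compound 2 to compound 3 (0.10 log units; within the scatter), a small step with wide uncertainty. The estimated value for compound 3 is 150000 nM, with an expected range from 60000 nM to 320000 nM.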

Compound 3, half-maximal cytotoxic concentration: 123000 nM
Beside the measured number, compound 3's estimate is 1.2-fold (0.09 log units) above it, and the stated range covers the measured number.
By their numbers in this assay, from the lowest: compounds 1, 3 and 2 (each within the scatter of the next).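

Within the data shown here, this is the first measured case of chloro in this spot, on an aromatic carbon ortho to a large group and meta to a methyl group, turning a 4-methylphenyl into a 2-chloro-4-methylphenyl. In this assay the change gives a 1.6-fold lower number from compound 2 to compound 3 (0.19 log units; within the scatter) and so cannot be told apart from no change, as was also true of the methyl swap, which gave a 2.0-fold higher number from compound 1 to compound 2 (0.30 log units; within the scatter) at a different place in the molecule; across these three compounds, then, neither single swap shifts the number by more than repeat measurements of this kind can differ. Nothing available here bears on why this chloro step came out as it did.

What remains open is whether any group at this position could move the number beyond the scatter, since a single chlorine atom is the only replacement for hydrogen shown here. An amine or a carboxylic acid in its place, or a longer chain such as propyl in place of the methyl group on the same ring, could show whether this part of the molecule matters in this assay at all.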